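Dropping the chloro from a hydrazone that shows no toxicity

A few compounds are considered here, and "the series" means these few. Any claim that something is new, unique, unknown or untested is made for them only; others in the source may bear on it.

Compound 1, `COc1ccc(OC)c(/C=C/c2nnc(Nc3ccc(Cl)cc3)o2)c1`: in a functional assay on NCI-H460 cells (Homo sapiens) for antiproliferative activity, read by sulforhodamine B assay, with a stated time of 48 h (on this read-out higher numbers stand for lower toxicity in this test and lower numbers for higher toxicity in this test), compound 1 gives only the limit > 100000 nM.
Compound 2, `COc1ccc(OC)c(/C=C/C(=O)N/N=C/c2ccc(Cl)cc2)c1`: in this assay compound 2 gives only the limit > 100000 nM.

Both measured compounds sit at the limit of > 100000 nM in this assay, at which 2 of the 2 values shown sit, so compound 2 stands exactly where every value stands, and no number separates it from compound 1. Neither compound has shown any toxicity within the range this assay can report.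

Compound 3, `COc1ccc(OC)c(/C=C/C(=O)N/N=C/c2ccccc2)c1`, has not yet been tested in this assay. Its difference from compound 2 is hydrogen in place of chloro on an aromatic carbon, in words hydrogen in place of chloro on an aromatic carbon. Within the data shown here, no step between measured compounds is available here to show what such a change does to the read-out, and the measured compounds offer no gradation at all, only limits. The step from compound 2 to compound 3 is therefore expected to be a step that the limit leaves unreadable from compound 2 to compound 3, none beyond the scatter. Compound 3 is accordingly estimated at 150000 nM, within a range from 50000 nM to 600000 nM, and it is most likely to be reported once more as a limit rather than a number.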

Compound 3, concentration lethal to 50% of the cells: 28300 nM
Estimate against measurement, compound 3: 5.3-fold (0.72 log units) above; measured number outside the range, below it.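

In this assay compound 2 gives > 100000 nM, which is a limit and not a number. With the change of 4-chlorophenyl to phenyl, the read-out comes within the measurable range, and the result is an at least 3.5-fold lower number from compound 2 to compound 3 (0.54 log units; beyond the scatter), so on this read-out the hydrazone shows toxicity once the chloro has gone. This shows that the position para to a large group on the aromatic ring is not indifferent in this series, something the earlier compounds could not show, as both stood at one and the same limit: the limit of > 100000 nM in this assay, at which 2 of the 3 values shown sit.

On these data alone, how far this reaches stays open, as a single step cannot tell whether the chloro is unusual in holding the read-out at the limit or whether other groups at this position, such as methoxy, an amine or a carboxylic acid, would do the same. As far as these compounds go, it is also open whether the same change of 4-chlorophenyl to phenyl on the core of compound 1 would bring that compound within the measurable range too.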